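One Methyl Group Added to Compound 1

This account rests on a few compounds, and the source may have more. Where it says the series, first, only, none or still open, it means among the compounds named here.

In a functional assay on RPMI-8226 cells (Homo sapiens) for cytotoxicity (on this read-out lower numbers stand for stronger inhibition and higher numbers for weaker inhibition), compound 1 `[O-]/[N+](=C\c1cc2ccccc2nc1SCc1ccccc1)c1ccccc1` gives 450 nM and stands level with compound 2 `COc1nc2ccccc2cc1/C=[N+](\[O-])c1ccccc1` at 450 nM on the same read-out. Compound 3 `Cc1ccc2nc(SCc3ccccc3)c(/C=[N+](\[O-])c3ccccc3)cc2c1` departs from compound 1 by a single change methyl in place of hydrogen on an aromatic carbon with methyl in place of hydrogen on an aromatic carbon of the shared core. Among the compounds with values here, only one measured step bears on this, the change no change at the digits printed from compound 1 to compound 2 (within the scatter) with methoxy in place of benzylsulfanyl. That step stays within the scatter, but it concerns another group, so its support is indirect. Within the data shown here, no measured compound carries the new methyl, and the data give no direction for it. The expected change is a 1.1-fold lower number from compound 1 to compound 3 (0.05 log units; within the scatter) and so no shift beyond the scatter is anticipated in this assay here. For compound 3 the estimated value is 400 nM with an expected range from 150 nM to 1100 nM in this measurement.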

Compound 3, half-maximal inhibitory concentration: 450 nM
Estimate against measurement, compound 3: 1.1-fold (0.05 log units) below, within the range that was stated.
By their numbers in this assay, from the lowest: compounds 1, 2 and 3 (each within the scatter of the next).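

In this assay, within the data shown here, the added methyl gives no change at the digits printed from compound 1 to compound 3 (within the scatter), the one direct reading for this position of the shared core. The earlier step, no change at the digits printed from compound 1 to compound 2 (within the scatter), concerned methoxy in place of benzylsulfanyl and said nothing about this carbon; now methyl in place of hydrogen, on a six-membered aromatic ring of carbon only, meta to a fused ring and para to a fused ring, is seen to cause no shift beyond the scatter. No supporting data accompany this reading that could account for it.

A single methyl does not show how an amine, a carboxylic acid or a longer chain on the same carbon would read. Going by these compounds, it also remains open whether the methyl would behave the same way alongside methoxy in place of benzylsulfanyl.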